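A few compounds are considered here, and "the series" means these few. Any claim that something is new, unique, unknown or untested is made for them only; others in the source may bear on it.

Measured compounds:
Compound 1 `CCN(CC)CCN(C)c1ccc(Nc2cc(NC3CC3)n3ncc(C#N)c3n2)cc1NC(C)=O` gives 27 uL/min in an ADME assay on cells (Hepatocyte, Rattus norvegicus) for metabolic stability; on this read-out lower numbers stand for slow clearance and higher numbers for fast clearance.
Compound 2 `CC(=O)Nc1cc(Nc2cc(NC3CC3)n3ncc(C#N)c3n2)ccc1N1CC[C@H](N(C)C)C1` gives 2.5 uL/min in this assay.

Going by the values given here, compound 2 stands as the lowest of the two numbers measured so far in this assay; its nearest neighbour is compound 1, and the gap between them is an 11-fold lower number from compound 1 to compound 2 (1.03 log units; beyond the scatter), the only step among the measured compounds. Compound 3 `CC(=O)Nc1cc(Nc2cc(NC3CC3)n3ncc(C#N)c3n2)ccc1N1CCC[C@@H](N(C)C)C1` has not yet been measured in this assay. It differs from compound 2 in one place: a group of 9 heavy atoms (7 carbon, 2 nitrogen; one six-membered non-aromatic ring with 1 hetero atom) in place of a group of 8 heavy atoms (6 carbon, 2 nitrogen; one five-membered non-aromatic ring with 1 hetero atom), on an aromatic carbon.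

That single measured step bears on the question only loosely. It shows that altering the amine-bearing substituent on that aromatic carbon can shift the number in this assay by a large margin, yet the change from compound 2 to compound 3 keeps the ring and both nitrogens and merely widens the ring by one carbon. On that basis compound 3 is expected to give a number close to that of compound 2, with a step of a 1.6-fold higher number from compound 2 to compound 3 (0.20 log units; within the scatter) that is expected to lie within the scatter. The estimate for compound 3 in this assay is 4 uL/min, ranging from 1.5 uL/min to 12 uL/min.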

Compound 3, intrinsic clearance in a liver preparation (reported as CLH), per the amount of preparation that the assay uses: < 1 uL/min
Compound 3 gave a limit, no number; the forecaster's own chance of this, stated with the estimate: 5%; middle value at least 4.0-fold (0.60 log units) away from the limit.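

In this assay compound 3 gives a limit and not a number, so its steps are bounded on one side only: the limit of < 1 uL/min in this assay, at which 1 of the 3 values shown sits. Going by these compounds alone, the earlier compounds showed only that a ring in place of an open chain at this aromatic carbon, ortho to an acetamido group and para to a large group, could go with a large shift; this result shows that the size of the ring matters too, since the six-membered ring in place of the five-membered one gives an at least 2.5-fold lower number from compound 2 to compound 3 (0.39 log units; beyond the scatter), and the number therefore responds to a change that keeps the dimethylamino group and both nitrogens. Against the open-chain group of compound 1, the same six-membered ring gives an at least 27-fold lower number from compound 1 to compound 3 (1.43 log units; beyond the scatter), so both ring compounds sit lower than the one open-chain compound shown.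

The compounds shown leave open how far under the limit compound 3 lies, and whether the opposite configuration at the defined stereocentre would read the same. They also leave open whether a seven-membered ring, a piperazine or a primary amine on the six-membered ring would hold the number this low.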